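Solubility notes on a chloropyridinyl-for-trifluoromethylphenyl exchange

A few compounds are considered here, and "the series" means these few. Any claim that something is new, unique, unknown or untested is made for them only; others in the source may bear on it.

The series is followed in a physicochemical assay for solubility, using the shake flask method, in simulated intestinal fluid, measured as kinetic solubility, with a stated time of 2 h, at 25 degrees C, at pH 6.5; on this read-out higher numbers stand for higher solubility and lower numbers for lower solubility. Compound 1 `Cc1nnc(-c2nc(C)c3c(c2N)C(=O)N(Cc2ccccc2)C3=O)o1` gives only a limit in this assay, < 5000 nM. Compound 2 `Cc1noc(-c2nc(C)c3c(c2N)C(=O)N(Cc2ccc(C(F)(F)F)cc2)C3=O)n1` likewise gives only a limit in this assay, < 5000 nM. Both measured values therefore sit at the same point, and compound 2 stands where compound 1 stands: the limit of < 5000 nM in this assay, at which 2 of the 2 values shown sit. Among the measured compounds shown here, no step between measured compounds is available, so nothing shows how a change on the saturated chain carbon bound to an amide-type nitrogen in a ring moves solubility. Compound 3 `Cc1noc(-c2nc(C)c3c(c2N)C(=O)N(Cc2ccc(Cl)cn2)C3=O)n1` is the next member, carrying (5-chloropyridin-2-yl in place of 4-(trifluoromethyl)phenyl on a saturated chain carbon bound to an amide-type nitrogen in a ring). With both measured values at a limit, the size of this step cannot be read from the series. The step from compound 2 to compound 3 is expected to be a number no lower from compound 2 to compound 3 (the limit leaves the size open), not clearly beyond the scatter. For compound 3 the estimate in this assay is 5000 nM, with a range from 1500 nM to 20000 nM.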

Compound 3, solubility: < 5000 nM
Compound 3: only a limit was reported (the forecaster's own chance of this, stated with the estimate: 50%); the middle value sits exactly at the limit.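

No step from compound 2 to compound 3 can be read, as both give only a limit: the limit of < 5000 nM in this assay, at which 3 of the 3 values shown sit.

The compounds shown leave open where the solubility of each actually lies in this assay, and whether 5-chloropyridin-2-yl in place of 4-(trifluoromethyl)phenyl moves it at all.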